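This account rests on a few compounds, and the source may have more. Where it says the series, first, only, none or still open, it means among the compounds named here.

Measured compounds in an assay on HEK293 cells for displacement of a labelled ligand from Melanocortin receptor 4 (Homo sapiens); on this read-out lower numbers stand for stronger inhibition and higher numbers for weaker inhibition:
- compound 1 `CC(C)C[C@H](N)c1cc(C(F)(F)F)ccc1N1CCN(C(=O)COc2ccc(Cl)cc2)CC1`: 2900 nM
- compound 2 `Cc1ccc(OCC(=O)N2CCN(c3ccc(C(F)(F)F)cc3[C@@H](N)CC(C)C)CC2)c(C)c1`: 4000 nM

Among the compounds with values here, compound 2 stands at the highest of the two numbers so far, but its only neighbour is compound 1, and the step of a 1.4-fold higher number from compound 1 to compound 2 (0.14 log units; within the scatter) lies within the scatter, so the two values cannot be ordered.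

The step under consideration leads to compound 3 `CC(C)C[C@H](N)c1cc(C(F)(F)F)ccc1N1CCN(C(=O)COc2cccc3ccccc23)CC1`. The change is naphthalen-1-yl in place of 2,4-dimethylphenyl on an oxygen on a saturated carbon, the same place in the shared core that was varied between compound 1 and compound 2.

Within the data shown here, only one measured step bears on this change: the exchange of one aryl group for another on that oxygen, from compound 1 to compound 2, which gave a 1.4-fold higher number from compound 1 to compound 2 (0.14 log units; within the scatter). That single step was within the scatter, and it says nothing about a fused two-ring group. With no further comparisons in this assay, the expectation for compound 3 is a number close to that of compound 2, the step of a 1.1-fold lower number from compound 2 to compound 3 (0.06 log units; within the scatter) being expected to stay within the scatter. Compound 3 is therefore estimated at 3500 nM, with a range of 1200 nM to 10000 nM.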

Compound 3, inhibition constant: 2600 nM
Compound 3: middle estimate off by 1.3-fold (0.13 log units), on the high side, within the range that was stated.
By their numbers in this assay, from the lowest: compounds 3, 1 and 2 (each within the scatter of the next).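

In this assay, going from a single aromatic ring to naphthalen-1-yl on the oxygen gives no step beyond the scatter, whether read against 2,4-dimethylphenyl (a 1.5-fold lower number from compound 2 to compound 3 (0.19 log units; within the scatter)) or against 4-chlorophenyl (a 1.1-fold lower number from compound 1 to compound 3 (0.05 log units; within the scatter)). The earlier pair compared only single-ring groups, whereas these steps extend the finding to a fused group with 2 six-membered aromatic rings of carbon only: among these three compounds, the number does not separate the groups on this oxygen. No measurement is available that would account for these three values.

Still open is whether a saturated cyclohexyl group, a pyridine ring or a carboxylic acid on the aromatic ring would move the number beyond the scatter at this place, as all three groups shown are aromatic carbon rings with no hydrogen-bond donors or acceptors. The compounds shown also say nothing about the rest of the shared core, such as a nitrile in place of the trifluoromethyl or an acetamide in place of the free amine.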